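The source may report more compounds than this note shows. Statements on the series, on what has been measured and on what is new or still open speak of the compounds shown alone.

Measured so far:
compound 1, `CC(C)CCc1ccc2c(NCCCNCc3ccco3)ccnc2c1`: in an ADME assay for permeability, using PAMPA, with a stated time of 30 min, at pH 7.4 (on this read-out lower numbers stand for lower permeability and higher numbers for higher permeability), compound 1 gives 23 10^-6 cm/s.
compound 2, `COc1cccc(CNCCCNc2ccnc3cc(CCC(C)C)ccc23)c1O`: in this assay compound 2 gives 23 10^-6 cm/s.

Compound 2 stands level with compound 1 on these numbers; the step of no change at the digits printed from compound 1 to compound 2 (within the scatter) lies within the scatter. Compound 3, `COc1ccccc1Oc1ccc2c(NCCCNCc3cccc(OC)c3O)ccnc2c1`, is not yet measured. It differs from compound 2 as follows: 2-methoxyphenoxy in place of isopentyl on an aromatic carbon.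

For the measured compounds named here, only one measured step exists, and it concerns a swap on a saturated chain carbon bound to an amine nitrogen, not on the aromatic carbon of the core that changes here. It bears on the present step only loosely: it shows that one substituent exchange in this series left this assay unchanged, but it says nothing direct about replacing isopentyl by 2-methoxyphenoxy. The expectation for compound 3 therefore rests on the structural change alone and carries a wide margin. A small downward step of a 1.5-fold lower number from compound 2 to compound 3 (0.19 log units; within the scatter) is expected for compound 3 in this assay, though a result within the scatter of compound 2 would not be surprising. Compound 3 is estimated at 15 10^-6 cm/s, with a range from 6 10^-6 cm/s to 35 10^-6 cm/s.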

Compound 3, apparent permeability: 317 10^-6 cm/s
For compound 3 the middle estimate is 21-fold (1.32 log units) below the measured one; measured number above the stated range.
By their numbers in this assay, from the lowest: compounds 1 and 2 (each within the scatter of the next); then compound 3.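

In this assay, the aromatic carbon of the shared core responds strongly to substitution: 2-methoxyphenoxy in place of isopentyl gives a large rise (a 14-fold higher number from compound 2 to compound 3 (1.14 log units; beyond the scatter)). For the compounds shown here, the one earlier step, at a saturated chain carbon bound to an amine nitrogen, showed no such movement (no change at the digits printed from compound 1 to compound 2 (within the scatter)), so the series is not uniformly flat on this read-out. At this carbon, exchanging a ringless chain for a larger group carrying an aromatic ring and hydrogen-bond acceptors did not lower the number; no measurement at hand accounts for the size of the step.

Which part of 2-methoxyphenoxy goes with the rise remains open, as the ether oxygen, the aromatic ring and the methoxy group all enter together; a plain phenoxy or a benzyl group on the same carbon would begin to separate them. Going by these compounds, it is also open whether the rise carries over to the furan-2-yl side chain of compound 1, and this single step gives no trend for the position.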